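The source may report more compounds than this note shows. Statements on the series, on what has been measured and on what is new or still open speak of the compounds shown alone.

The study sets three compounds side by side in a functional assay on CNE-2 cells (Homo sapiens) for cytotoxicity, read by sulforhodamine B assay, with a stated time of 48 h; on this read-out higher numbers stand for weaker inhibition and lower numbers for stronger inhibition. Compound 1 `Nc1ccc(C(=O)/C=C/c2ccc(O)c(F)c2)cc1-c1ccc(F)cc1` gives 18100 nM, compound 2 `COc1ccc(/C=C/C(=O)c2ccc(N)c(-c3ccc(F)cc3)c2)cc1OC` gives 3510 nM, and compound 3 `COc1ccc(/C=C/C(=O)c2cccc(-c3cccc(F)c3)c2)cc1OC` gives 770 nM. Among these numbers compound 2 stands second highest: compound 3 sits below it beyond the scatter, and compound 1 sits above it beyond the scatter. Compound 4 `COc1ccc(/C=C/C(=O)c2cccc(-c3ccc(F)cc3)c2)cc1OC` has not yet been measured. It differs from compound 2 by hydrogen in place of amino on an aromatic carbon. Compound 3 likewise carries hydrogen in place of amino and gives 770 nM. On that basis the step is expected to be a 3.9-fold lower number from compound 2 to compound 4 (0.59 log units; beyond the scatter), a fall beyond the scatter in this assay. Compound 4 is therefore estimated at 900 nM, in a range from 350 nM to 2500 nM.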

Compound 4, half-maximal inhibitory concentration: 5550 nM
Estimate against measurement, compound 4: 6.2-fold (0.79 log units) below; the measured number lies above the stated range.
By their numbers in this assay, from the lowest: compound 3; then compounds 2 and 4 (each within the scatter of the next); then compound 1.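

In this assay, hydrogen in place of amino, ortho to a 4-fluorophenyl group, gives a 1.6-fold higher number from compound 2 to compound 4 (0.20 log units; within the scatter), so the amino group makes no readable difference at this position with this neighbour. The larger step comes from the other change, 4-fluorophenyl in place of 3-fluorophenyl, which gives a 7.2-fold higher number from compound 3 to compound 4 (0.86 log units; beyond the scatter). Nothing available accounts for either step.

From the compounds shown here alone, whether the exchange of amino for hydrogen reads the same alongside 3-fluorophenyl remains open. So does the effect of a hydroxyl or methoxy group on this aromatic carbon, or of a 2-fluorophenyl group.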